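Reversing a Large Lipophilicity Drop: Compound 3 to Compound 4

The source may hold more compounds than are shown below. What is called first, only, known or untested is meant among the compounds shown, and "the series" means these compounds.

Compound 1 `O=C(Nc1ccccc1)c1cnc(NCc2c(F)ccc3c2CCO3)n2cnnc12` gives 4.1 in a physicochemical assay for lipophilicity, using the shake flask method, in phosphate buffer, measured as octanol-water partition, with a stated time of 30 min, at pH 7.4; a lower number here means a more polar compound, a higher number a more lipophilic compound. Compound 2 `Fc1ccc2c(c1CNc1ncc(Nc3ccccc3)c3nncn13)CCO2` gives 3.3 in this assay, and compound 3 `C[C@@H]1CC(=O)N(c2cnc(NCc3c(F)ccc4c3CCO4)n3cnnc23)C1` gives 1.8, the lowest of the three numbers, with the others well beyond the scatter. Compound 4 `CN(C(=O)c1ccccc1)c1cnc(NCc2c(F)ccc3c2CCO3)n2cnnc12` differs from compound 3 in one place: benzoyl(methyl)amino in place of 4-methyl-2-oxopyrrolidin-1-yl on an aromatic carbon. The step of a number 2.30 log units lower from compound 1 to compound 3 (beyond the scatter) shows how much the group that now leaves compound 3 lowered the number when it displaced a closely related phenyl amide, and a number 1.50 log units lower from compound 2 to compound 3 (beyond the scatter) points the same way. A large rise is therefore expected, a number 2.30 log units higher from compound 3 to compound 4 (beyond the scatter), bringing compound 4 back near compound 1. Compound 4 is estimated at 4.1, within 3.5 to 4.7.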

Compound 4, distribution coefficient: 2.4
Compound 4: the middle estimate sits 1.70 log units above what was measured, outside the stated range (below it).
By their numbers in this assay, from the lowest: compound 3; then compound 4; then compound 2; then compound 1.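

At this aromatic carbon, a phenyl ring in the entering group does not by itself restore the high number in this assay: benzoyl(methyl)amino gives a number 0.60 log units higher from compound 3 to compound 4 (beyond the scatter), while replacing phenylcarbamoyl with it gives a number 1.70 log units lower from compound 1 to compound 4 (beyond the scatter). Replacing anilino with it gives a number 0.90 log units lower from compound 2 to compound 4 (beyond the scatter), so among these three phenyl-bearing groups, how the ring is attached matters, not only its presence. No measurement here explains these gaps. Still open, as far as these compounds go, is how much of the gap to compound 1 belongs to the methyl, a question that benzoylamino, with the amide hydrogen in the methyl's place, could help separate.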